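This account rests on a few compounds, and the source may have more. Where it says the series, first, only, none or still open, it means among the compounds named here.

Compound 3 `O=C(Nc1cccc(Cl)c1)c1ccc2cccc(O)c2n1` was examined in an ADME assay on THP-1 cells (Homo sapiens) for cytotoxicity, read by WST assay, with a stated time of 24 h; on this read-out lower numbers stand for stronger inhibition and higher numbers for weaker inhibition. In this assay compound 3 gives > 30000 nM, a limit rather than a number. Compound 1 `Cc1ccccc1NC(=O)c1ccc2cccc(O)c2n1` in this assay gives > 30000 nM, also a limit. Compound 2 `O=C(Nc1cccc(F)c1)c1ccc2cccc(O)c2n1` in this assay gives > 30000 nM, again a limit. Compound 3 thus stands exactly where the other two values stand, at the limit of > 30000 nM in this assay, at which 3 of the 3 values shown sit, so nothing places it higher or lower than either of them.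

Compound 4 `O=C(Nc1ccc(Br)cc1)c1ccc2cccc(O)c2n1` has not yet been measured; it differs from compound 3 by 4-bromophenyl in place of 3-chlorophenyl on an amide-type nitrogen. Of the measured steps, a step that the two limits leave unreadable from compound 1 to compound 3 and a step that the two limits leave unreadable from compound 2 to compound 3 lead into the same limit, and a step that the two limits leave unreadable from compound 1 to compound 2 joins two limits; none has a readable size, so neither a step within the usual scatter nor one beyond it can be taken from them. For compound 4 the expectation is therefore that the limit is reached again, with an estimated 50000 nM and a range from 20000 nM to 150000 nM. For compound 4 the expected step is a step that the limit leaves unreadable from compound 3 to compound 4, none beyond the scatter.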

Compound 4, half-maximal inhibitory concentration: > 30000 nM
Compound 4 ended at the assay's limit (the forecaster's own chance of this, stated with the estimate: 85%); the middle value is on the limit's open side.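

In this assay the steps from compound 4 to compound 1, compound 2 and compound 3 cannot be read, since all four compounds stop at one limit: the limit of > 30000 nM in this assay, at which 4 of the 4 values shown sit.

The compounds shown leave open whether any of these changes on the amide-type nitrogen alters cytotoxicity in this assay.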